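The source may report more compounds than this note shows. Statements on the series, on what has been measured and on what is new or still open speak of the compounds shown alone.

Measured compounds:
compound 1 `CCCCCC(=O)OCc1ccc2oc(=O)c(C(=O)Oc3cccc(Br)c3)cc2c1` — 59.3%
compound 2 `O=C(Oc1cccc(F)c1)c1cc2cc([N+](=O)[O-])ccc2oc1=O` — 53.6%
compound 3 `O=C(Oc1cccc(Cl)c1)c1cc2cc(CCl)ccc2oc1=O` — 79.8%

These three compounds share a core and were tested in a functional assay on HT-1080 cells (Homo sapiens), read by transwell migration, with a stated time of 24 h, tested at 1 uM; a higher number here means a weaker effect of the compound at the concentration tested, a lower number a stronger effect. Among the three numbers, compound 1 stands second highest. Its value and that of compound 2 lie within the usual scatter of each other, so nothing separates them. Compound 3 gives the highest number, and its gap to compound 1 lies beyond the scatter, so compound 3 shows the weaker effect at this concentration.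

The next compound, compound 4 `NCc1ccc2oc(=O)c(C(=O)Oc3cccc(Br)c3)cc2c1`, has not yet been measured in this assay. It differs from compound 1 in one place: amino in place of (pentylcarbonyl)oxy on a saturated chain carbon bound to an aromatic carbon. Going by the values given here, no pair of measured compounds differing in one place is available, so there is no measured step to lean on.

The step from compound 1 to compound 4 is expected to be small, with no clear direction beyond the scatter, as the estimated a number 0.7 percentage points higher from compound 1 to compound 4 (within the scatter) indicates. Compound 4 is therefore estimated at about 60%, within a range from 40% to 80%.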

Compound 4, a percentage reported as activity, at one concentration (the size of the read-out at that concentration, not a potency): 79.3%
For compound 4 the middle estimate is 19.3 percentage points below the measured one; measured number inside the range.
By their numbers in this assay, from the lowest: compounds 2 and 1 (each within the scatter of the next); then compounds 4 and 3 (each within the scatter of the next).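

Exchanging the (pentylcarbonyl)oxy group for amino gives a number 20 percentage points higher from compound 1 to compound 4 (beyond the scatter) in this assay, the first measured sign that the effect at the concentration tested responds to what this position carries. The change replaces a group of 8 heavy atoms with one of 1 heavy atom and also adds a hydrogen-bond donor, so this single step cannot separate these differences from one another. No measurement shown accounts for the step.

The compounds shown leave open whether the effect depends on the length of the acyl chain, which a shorter acetyloxy or a longer octanoyloxy group on the same carbon of compound 1 would address. They also leave open how a hydroxyl or a dimethylamino group there would compare with amino.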